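Replacing phenyl with thiophen-2-yl in a small series

The source may hold more compounds than are shown below. What is called first, only, known or untested is meant among the compounds shown, and "the series" means these compounds.

Compound 1 `S=C(NCc1cccnc1)SCCc1nc2ccccc2o1`: 2880 nM
Compound 2 `S=C(NCc1cccnc1)SCCc1nnc(-c2ccccc2)o1`: 1230 nM

Among the compounds with values here, only two compounds have been measured so far, both in a functional assay on Bel-7402 cells (Homo sapiens) for cytotoxicity, read by resazurin assay, with a stated time of 72 h; on this read-out lower numbers stand for stronger inhibition and higher numbers for weaker inhibition. Here a lower number means stronger inhibition of the cells. Compound 2, at 1230 nM, holds the lower of the two numbers, and its gap to compound 1 lies beyond the usual scatter of repeated measurements. These two compounds differ in more than one place, so their gap says little about any single change.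

The next compound, compound 3 `S=C(NCc1cccnc1)SCCc1nnc(-c2cccs2)o1`, differs from compound 2 in one place. It carries thiophen-2-yl in place of phenyl on an aromatic carbon. Both groups are single aromatic rings with no net charge, and the rest of the molecule stays the same. Within the data shown here, no measured pair shows this swap, so the expectation rests on compound 2 at 1230 nM and on the modest size of the change. The estimated step is a 1.1-fold higher number from compound 2 to compound 3 (0.02 log units; within the scatter), which is expected to stay within the scatter, with no clear direction. For compound 3 the expected value is 1300 nM, with an estimated range from 550 nM to 3000 nM.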

Compound 3, half-maximal inhibitory concentration: 1340 nM
Beside the measured number, compound 3's estimate is 1.0-fold (0.01 log units) below it; the range from low to high includes it.
By their numbers in this assay, from the lowest: compounds 2 and 3 (each within the scatter of the next); then compound 1.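

In this assay, putting thiophen-2-yl in place of phenyl gives a 1.1-fold higher number from compound 2 to compound 3 (0.04 log units; within the scatter), so at this aromatic carbon of the five-membered aromatic ring with 2 nitrogen and 1 oxygen the two groups cannot be told apart on this read-out. Within the data shown here, this is the first step that changes only one place, so unlike the gap between compound 1 and compound 2, it can be read as the result of a single swap: a six-membered carbon ring can give way to a five-membered ring holding sulfur with no change beyond the scatter. Nothing measured here bears on why the two groups read alike.

The compounds shown leave open whether this position accepts anything other than a single aromatic ring with no net charge, such as an amine, a carboxylic acid or a longer alkyl chain. They also leave open how the other parts of the molecule, identical in compound 2 and compound 3, contribute to the inhibition of these cells.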